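The compounds below may be only part of what the source reports. "The series", "measured", "known", "first", "only" and "open" are said of these compounds alone.

Measured compounds in an assay on isolated protein for inhibition of ubiquitin carboxyl-terminal hydrolase 1 (Homo sapiens); on this read-out lower numbers stand for stronger inhibition and higher numbers for weaker inhibition:
- compound 1, `CC(=O)Nc1nc2ccccn2c1-c1ccc(O)cc1`: > 100000 nM, a limit of the assay and not a number.
- compound 2, `Nc1nc2ccccn2c1-c1ccc(O)cc1`: > 100000 nM, a limit of the assay and not a number.
- compound 3, `Nc1nc2cc(C(F)(F)F)ccn2c1-c1ccc(O)cc1`: > 100000 nM, a limit of the assay and not a number.

Compound 3 therefore stands nowhere readable in this assay: its value is a limit only, and the two other values shown in the series are limits as well, all of them sitting at the limit of > 100000 nM in this assay, at which 3 of the 3 values shown sit. The step from compound 1 to compound 2 is a step that the two limits leave unreadable from compound 1 to compound 2, and the step from compound 2 to compound 3 is a step that the two limits leave unreadable from compound 2 to compound 3; neither has a readable size.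

Compound 4 is `Cc1ccn2c(-c3ccc(O)cc3)c(N)nc2c1`. Relative to compound 3 the change is methyl in place of trifluoromethyl on an aromatic carbon. Within the data shown here, of the measured steps, the step from compound 2 to compound 3 concerns the same position, with trifluoromethyl entering in place of hydrogen, but its size is not readable, so no measured step gives a usable size for the present change. No movement beyond the scatter can be read into the new step from what is shown.

Compound 4 is accordingly expected to remain at the limit as well, with an estimate of 150000 nM and a range from 40000 nM to 600000 nM, which as a step means an expected step that the limit leaves unreadable from compound 3 to compound 4.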

Compound 4, half-maximal inhibitory concentration: > 100000 nM
Compound 4: no number, only a limit; the forecaster's own chance of this, stated with the estimate: 85%; the middle value does not contradict the limit.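

In this assay compound 4 gives > 100000 nM as a limit of the assay and not a number. No new step can be read from compound 2 or compound 3 to compound 4, and all the compounds shown sit at one limit: the limit of > 100000 nM in this assay, at which 4 of the 4 values shown sit.

The compounds shown leave open whether any change on the shared core gives a readable value in this read-out.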